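This account rests on a few compounds, and the source may have more. Where it says the series, first, only, none or still open, it means among the compounds named here.

Compound 3 `O=C1/C(=C/c2ccncc2)CN(S(=O)(=O)c2ccc(F)cc2)C/C1=C\c1ccccc1F` gives > 20000 nM in a functional assay on SMMC-7721 cells (Homo sapiens) for cytotoxicity, read by MTT assay, with a stated time of 24 h (on this read-out lower numbers stand for stronger inhibition and higher numbers for weaker inhibition), which is a limit of the assay and not a number. That places it at the limit of > 20000 nM in this assay, at which 1 of the 3 values shown sits. Compound 2 `O=C1/C(=C/c2ccncc2)CNC/C1=C\c1ccccc1F`, which has no sulfonyl group, gives 18400 nM in this assay. Installing the (4-fluorophenyl)sulfonyl group gives an at least 1.0-fold higher number from compound 2 to compound 3 (0.03 log units; that floor lies within the scatter). Compound 4 `O=C1/C(=C/c2ccncc2)CN(S(=O)(=O)c2ccc(Br)cc2)C/C1=C\c1ccccc1F` keeps the rest of compound 3 and has bromo in place of fluoro on an aromatic carbon. Going by the values given here, no measured step makes this exchange, so the step above bears on it only indirectly. The closest guide is compound 1 `O=C1/C(=C/c2cccnc2)CN(S(=O)(=O)c2ccc(Br)cc2)C/C1=C\c1ccccc1F`, which carries the same (4-bromophenyl)sulfonyl group, differs elsewhere in its structure and gives 9100 nM. On the strength of compound 1 at 9100 nM, a modest move towards a lower number is expected. Compound 4 may still stay close to the limit seen for compound 3. The estimated change is an at least 1.5-fold lower number from compound 3 to compound 4 (0.18 log units; that floor lies within the scatter). The estimate for compound 4 is 13000 nM, with an expected range from 6000 nM to 20000 nM.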

Compound 4, half-maximal inhibitory concentration: 12600 nM
Compound 4: middle estimate off by 1.0-fold (0.01 log units), on the high side, and the stated range covers the measured number.
By their numbers in this assay, from the lowest: compounds 1, 4 and 2 (each within the scatter of the next, the first and the last beyond it). At a limit, above all of these: compound 3.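

In this assay, going from 4-fluorophenyl to 4-bromophenyl gives an at least 1.5-fold lower number from compound 3 to compound 4 (0.20 log units; that floor lies within the scatter), so this first look at the exchange at this position establishes no effect of it. The value of compound 3 is a limit of the assay and not a number: the limit of > 20000 nM in this assay, at which 1 of the 4 values shown sits. With bromo in place, adding the sulfonyl group to the amine nitrogen in the ring gives a 1.5-fold lower number from compound 2 to compound 4 (0.16 log units; within the scatter), and exchanging pyridin-3-yl for pyridin-4-yl gives a 1.4-fold higher number from compound 1 to compound 4 (0.14 log units; within the scatter), so neither change is shown to shift this read-out.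

From the compounds shown here alone, whether a 4-chlorophenyl, 4-methoxyphenyl or 4-aminophenyl group here would give a number beyond the scatter remains open. Also open, going by these compounds, is whether the exchange of fluoro for bromo would read the same with pyridin-3-yl in place of pyridin-4-yl.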